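The compounds below may be only part of what the source reports. "The series", "measured", "known", "first", "only" and "open" are said of these compounds alone.

Measured so far:
compound 1, `COc1ccc(N(C)c2nc(NC3CCCC3)c3ccccc3n2)cc1`: 9400 nM
compound 2, `COc1ccc(N(C)c2nc(NCCCO)c3ccccc3n2)cc1`: 13000 nM
compound 3, `N#Cc1ccc(Nc2nc(NC3CCCC3)c3ccccc3n2)cc1`: > 31300 nM

All three values come from a functional assay on A549 cells (Homo sapiens) for antiproliferative activity, read by sulforhodamine B assay, with a stated time of 48 h; a lower number here means a stronger inhibitor of growth, a higher number a weaker inhibitor of growth. Compound 4, `N#Cc1ccc(Nc2nc(NCCCO)c3ccccc3n2)cc1`, has not yet been measured there.

Compound 1 and compound 2 share one core and differ only by 3-hydroxypropyl in place of cyclopentyl on a nitrogen on an aromatic ring. In this assay the step is a 1.4-fold higher number from compound 1 to compound 2 (0.14 log units; within the scatter), so the two compounds sit together and no order between them can be read.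

For compound 3 this assay reports only a limit and not a number: compound 3 gives > 31300 nM, which is the limit of > 31300 nM in this assay, at which 1 of the 3 values shown sits. How the core of compound 3 differs from the core of compound 1 is not broken down here.

Compound 4 differs from compound 3 by 3-hydroxypropyl in place of cyclopentyl on a nitrogen on an aromatic ring. This is the same change as from compound 1 to compound 2, at the same kind of place with the same neighbours, so it is the same change made on a second core. A step of about the same size is expected, namely a step that the limit leaves unreadable from compound 3 to compound 4, because the earlier instance gave a 1.4-fold higher number from compound 1 to compound 2 (0.14 log units; within the scatter).

Since compound 3 already stands at the limit of the assay, a step of that size would leave compound 4 at or beyond the limit as well. Compound 4 is therefore expected to give 45000 nM, with a likely range from 20000 nM to 120000 nM. The assay is thought more likely than not to return only a limit for compound 4 again.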

Compound 4, concentration for 50% growth inhibition: 3000 nM
Beside the measured number, compound 4's estimate is 15-fold (1.18 log units) above it, and the stated range ends above it.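

In this assay, 3-hydroxypropyl in place of cyclopentyl gives an at least 10-fold lower number from compound 3 to compound 4 (1.01 log units; beyond the scatter), whereas the same change on the core of compound 1 gives a 1.4-fold higher number from compound 1 to compound 2 (0.14 log units; within the scatter). The change therefore does not keep its size when carried to the second core, and the step on one core is no guide to the step on the other: the same change on two cores in this assay, a 1.4-fold higher number (0.14 log units; within the scatter) from compound 1 to compound 2 and an at least 10-fold lower number (1.01 log units; beyond the scatter) from compound 3 to compound 4, at least 14-fold (1.15 log units) apart, beyond the scatter of two such steps

Compound 3 gives > 31300 nM, which is a limit and not a number, so the step to compound 4 has a known minimum size only, and these two pairs show neither which feature of the cores separates the outcomes nor any rule for further cores.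

Still open, from the compounds shown here alone, is whether the step on the core of compound 3 follows from the hydroxyl of the 3-hydroxypropyl or from the loss of the cyclopentyl ring, a question that a plain propyl chain, a longer chain ending in hydroxyl, or a chain ending in an amine could help to settle. Also open, going by these compounds, is which difference between the cores matters, which a core combining the nitrile of compound 3 with the methyl group on the nitrogen of compound 1 could begin to address.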